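Combining Two Changes Against NADPH Oxidase 2

The source may hold more compounds than are shown below. What is called first, only, known or untested is meant among the compounds shown, and "the series" means these compounds.

Measured compounds:
Compound 1, `CCN(CC)c1ccc(/C=C2\C(=O)N(C3CCCCC3)C(=S)N2C)cc1`: 5660 nM in an assay on isolated protein for inhibition of NADPH oxidase 2 (Homo sapiens), read by chemiluminescence, in the presence of a further agent that is not named here; a higher number here means a weaker inhibitor, a lower number a stronger inhibitor
Compound 2, `CN1C(=S)N(C2CCCCC2)C(=O)/C1=C\c1ccc(N(C)CCCO)cc1`: 2400 nM
Compound 3, `CCN(CC)c1ccc(/C=C2\C(=O)N(C3CCCCC3)C(=S)N2C)c(O)c1`: 1660 nM

Compound 4, `CN1C(=S)N(C2CCCCC2)C(=O)/C1=C\c1ccc(N(C)CCCO)cc1O`, has not yet been measured. Two single changes are known. From compound 1 to compound 2 the difference is (3-hydroxypropyl)(methyl)amino in place of diethylamino on an aromatic carbon, and this step was a 2.4-fold lower number from compound 1 to compound 2 (0.37 log units; beyond the scatter). From compound 1 to compound 3 the difference is hydroxy in place of hydrogen on an aromatic carbon, with a 3.4-fold lower number from compound 1 to compound 3 (0.53 log units; beyond the scatter). Compound 4 differs from compound 3 by (3-hydroxypropyl)(methyl)amino in place of diethylamino on an aromatic carbon; this is the same kind of change as from compound 1 to compound 2, though here the place is also meta to a hydroxy group (1 heavy atom). Compound 4 is therefore expected to show a step of a 2.1-fold lower number from compound 3 to compound 4 (0.32 log units; beyond the scatter), resting on the earlier step of a 2.4-fold lower number from compound 1 to compound 2 (0.37 log units; beyond the scatter), taken as roughly carrying over. Compound 4 is estimated at 800 nM, between 350 nM and 2000 nM.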

Compound 4, half-maximal inhibitory concentration: 3390 nM
Compound 4: middle estimate off by 4.2-fold (0.63 log units), on the low side; measured number outside the range, above it.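

In this assay, with the hydroxy group on the aromatic ring, the swap to (3-hydroxypropyl)(methyl)amino gave a 2.0-fold higher number from compound 3 to compound 4 (0.31 log units; beyond the scatter) and so did not repeat its earlier step: the same change on two cores in this assay, a 2.4-fold lower number (0.37 log units; beyond the scatter) from compound 1 to compound 2 and a 2.0-fold higher number (0.31 log units; beyond the scatter) from compound 3 to compound 4, 4.8-fold (0.68 log units) apart, beyond the scatter of two such steps. The hydroxy change did not carry over either, giving a 1.4-fold higher number from compound 2 to compound 4 (0.15 log units; within the scatter) on the core that bears the (3-hydroxypropyl)(methyl)amino group: the same change on two cores in this assay, a 3.4-fold lower number (0.53 log units; beyond the scatter) from compound 1 to compound 3 and a 1.4-fold higher number (0.15 log units; within the scatter) from compound 2 to compound 4, 4.8-fold (0.68 log units) apart, beyond the scatter of two such steps. This shows that in these four compounds the two changes do not simply add up, but it does not show why, or whether the same holds for other groups.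

From the compounds shown here alone, it stays open whether a longer chain would behave in the same way. The same goes for an amine or a carboxylic acid in place of the chain's hydroxy group.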